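The compounds below may be only part of what the source reports. "The series", "measured", "known", "first", "only" and "open" are said of these compounds alone.

Measured so far in a functional assay on the whole organism for inhibition, with Rattus norvegicus as the target; a higher number here means that more compound is needed for the effect, a lower number that less compound is needed:
Compound 1 `CC(Cc1ccc(Cl)cc1)(Oc1ccc(Cc2ccccc2)cc1)C(=O)O` gives 1 mg/kg
Compound 2 `COc1ccc(Cc2ccc(OC(C)(Cc3ccc(Cl)cc3)C(=O)O)cc2)cc1` gives < 10 mg/kg as a limit

As far as these compounds go, for compound 2 the reading < 10 mg/kg is a limit and not a number, so its exact place in the assay is unknown. Compound 3 `CC(Cc1ccc(Cl)cc1)(Oc1ccc(Cc2ccc(Cl)cc2)cc1)C(=O)O` differs from compound 2 in one place: chloro in place of methoxy on an aromatic carbon, taking 4-methoxybenzyl to 4-chlorobenzyl (chloro in place of methoxy on an aromatic carbon). For the measured compounds named here, only one measured step touches this carbon, methoxy in place of hydrogen on an aromatic carbon. That step is a step that the limit leaves unreadable from compound 1 to compound 2 and offers neither a size nor a direction for the new exchange. Going by the values given here, no measured compound yet carries chloro at this place. Among the compounds with values here, the expectation therefore leans on compound 1 at 1 mg/kg as the only firm number, and compound 3 is expected to fall in the same region, with no step of a set direction foreseen. The estimated move is a step that the limit leaves unreadable from compound 2 to compound 3 and remains loose, since it starts from a limit. Compound 3 is expected at 2 mg/kg with an estimated range from 0.4 mg/kg to 10 mg/kg in this assay.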

Compound 3, dose for half-maximal effect: > 10 mg/kg
Compound 3 was reported as a limit; the forecaster's own chance of this, stated with the estimate: 25%; at least 5.0-fold (0.69 log units) between middle value and limit.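

In this assay, for the compounds shown here, chloro in place of hydrogen on this aromatic carbon, para to a large group, gives an at least 10-fold higher number from compound 1 to compound 3 (1.00 log units; beyond the scatter), so this is the first readable evidence that a change at this place can raise the dose needed for the effect. The reading for compound 3 is a limit and not a number: the limit of > 10 mg/kg in this assay, at which 1 of the 3 values shown sits. The reading for compound 2 is also a limit and not a number: the limit of < 10 mg/kg in this assay, at which 1 of the 3 values shown sits. Chloro in place of methoxy gives a number no lower from compound 2 to compound 3 (the limit leaves the size open), and the step that puts methoxy in place of hydrogen cannot be read, so the exchange of methoxy for chloro has no size and methoxy has no firm place beside hydrogen.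

The compounds shown leave open how far compound 3 really lies from compound 1 and where methoxy stands relative to hydrogen, so no full order of hydrogen, methoxy and chloro at this carbon can be given. As far as these compounds go, it also remains open whether the rise in dose belongs to chloro alone or would also appear with fluoro, a hydroxyl or an amine on the same carbon in this assay.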